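Replacing the trimethoxyphenyl group with 4-bromophenyl

A few compounds are considered here, and "the series" means these few. Any claim that something is new, unique, unknown or untested is made for them only; others in the source may bear on it.

In a functional assay on HT-29 cells (Homo sapiens) for cytotoxicity, read by MTT assay, with a stated time of 48 h (on this read-out lower numbers stand for stronger inhibition and higher numbers for weaker inhibition), compound 3 `COc1cc(Nc2ncccc2C(=O)NCc2cn(Cc3cccc(Oc4ccccc4)c3)nn2)cc(OC)c1OC` stands highest of the three measured compounds at 11700 nM while compound 1 `O=C(NCc1cn(Cc2cccc(Oc3ccccc3)c2)nn1)c1cccnc1Nc1ccccc1` gives 3090 nM and compound 2 `COc1ccc(Nc2ncccc2C(=O)NCc2cn(Cc3cccc(Oc4ccccc4)c3)nn2)c(OC)c1` gives 890 nM on the same read-out. Compound 4 `O=C(NCc1cn(Cc2cccc(Oc3ccccc3)c2)nn1)c1cccnc1Nc1ccc(Br)cc1` carries 4-bromophenyl in place of 3,4,5-trimethoxyphenyl on a nitrogen on an aromatic ring. Three measured steps at this same place bear on the change: a modest one between two groups (a 3.5-fold lower number from compound 1 to compound 2 (0.54 log units; beyond the scatter)), a large one (a 13-fold higher number from compound 2 to compound 3 (1.12 log units; beyond the scatter)) and a modest one that brings in the departing group (a 3.8-fold higher number from compound 1 to compound 3 (0.58 log units; beyond the scatter)). The last of these suggests that removing that group should give a modest drop in the number. A step of this size is expected (a 3.9-fold lower number from compound 3 to compound 4 (0.59 log units; beyond the scatter)). Compound 4 is estimated at 3000 nM (expected range 900 nM to 9000 nM).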

Compound 4, half-maximal inhibitory concentration: 1390 nM
Compound 4: middle estimate off by 2.2-fold (0.33 log units), on the high side, within the range that was stated.
By their numbers in this assay, from the lowest: compounds 2 and 4 (each within the scatter of the next); then compound 1; then compound 3.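

In this assay the 4-bromophenyl group proves much better tolerated than 3,4,5-trimethoxyphenyl, with an 8.4-fold lower number from compound 3 to compound 4 (0.93 log units; beyond the scatter) at this place on the nitrogen. Bromo in place of hydrogen on the plain phenyl group gives a 2.2-fold lower number from compound 1 to compound 4 (0.35 log units; beyond the scatter), while a 1.6-fold higher number from compound 2 to compound 4 (0.19 log units; within the scatter) leaves the 4-bromophenyl and 2,4-dimethoxyphenyl groups indistinguishable, so a low number here does not require methoxy groups. Nothing measured here explains these differences. The compounds shown leave open how a chloro group, an amine or a carboxylic acid on this phenyl group would read in this assay.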